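Pentyloxy to pentenyloxy on the shared core

The source may hold more compounds than are shown below. What is called first, only, known or untested is meant among the compounds shown, and "the series" means these compounds.

Compound 1 `CCCCCOC1(c2ccc(Cl)cc2)SC=C(C)n2c1noc2=O`: > 100000 nM
Compound 2 `CC1=CSC(O)(c2cccc(C(F)(F)F)c2)c2noc(=O)n21`: 71000 nM
Compound 3 `CCCCCCCCCCCCCCCOC1(c2ccc(Cl)cc2)SC=C(C)n2c1noc2=O`: > 100000 nM

In a functional assay on A2780/DX3 cells (Homo sapiens) for antiproliferative activity, read by MTT assay, with a stated time of 3 days (a higher number here means a weaker inhibitor, a lower number a stronger inhibitor), compound 1 gives > 100000 nM, which is a limit of the assay and not a number. Compound 3 likewise gives only a limit, > 100000 nM. Compound 2 gives 71000 nM. Compound 4 `CC/C=C/COC1(c2ccc(Cl)cc2)SC=C(C)n2c1noc2=O` differs from compound 1 by but-1-en-1-yl in place of butyl on a saturated chain carbon bound to an oxygen on a saturated carbon. For the measured compounds named here, the only measured step on this core, a step that the two limits leave unreadable from compound 1 to compound 3, cannot be read, since both of its ends sit at the limit of > 100000 nM in this assay, at which 2 of the 3 values shown sit. Going by the values given here, no measured step therefore tells what size to expect for the change from compound 1 to compound 4, and the expectation rests on compound 1 standing at its limit. Compound 4 is expected to give 100000 nM (range 30000 nM to 300000 nM), a step of a number no higher from compound 1 to compound 4 (the limit leaves the size open) that is expected to stay within the scatter.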

Compound 4, half-maximal inhibitory concentration: 88000 nM
Beside the measured number, compound 4's estimate is 1.1-fold (0.06 log units) above it; low and high end bracket the measured number.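

For the compounds shown here, with pent-2-en-1-yl on the oxygen, compound 4 gives 88000 nM in this assay, a number and not a limit, the first such value for an alkoxy chain on the shared core. Pentyl to pent-2-en-1-yl is an at least 1.1-fold lower number from compound 1 to compound 4 (0.05 log units; that floor lies within the scatter), so the true size of this change stays unknown and only its floor can be stated. The values of compound 1 and compound 3 are limits, and the step between them cannot be read: the limit of > 100000 nM in this assay, at which 2 of the 4 values shown sit.

On these data alone, whether a shorter chain, or an amine or a carboxylic acid at the end of the chain, would give a number clearly beyond the scatter remains open.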